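Nitro in Place of Chloro on the Fused Ring

The source may report more compounds than this note shows. Statements on the series, on what has been measured and on what is new or still open speak of the compounds shown alone.

Of the compounds shown here, three built on a shared core have been measured, each carrying a chloro on the fused ring and differing in the side chain attached to the core. In a functional assay on the whole organism (Hindlimb, strain albino) with Mus musculus as the target, in the maximal electroshock model, with a stated time of 0.5 h (a higher number here means that more compound is needed for the effect, a lower number that less compound is needed), compound 1 `COc1ccc(C2CC(Nc3nc4ccc(Cl)cc4s3)=NN2C(C)=O)cc1` gives 93.3 umol/kg, compound 3 `O=C(/C=C/c1ccc(Cl)cc1)Nc1nc2ccc(Cl)cc2s1` gives 204 umol/kg, and compound 2 `O=C(/C=C/OC1=CC=C1)Nc1nc2ccc(Cl)cc2s1` gives 544 umol/kg, the highest of the three numbers, with compound 3 nearest to it and compound 1 furthest from it. Going by the values given here, only one measured pair differs in a single place: a 2.7-fold lower number from compound 2 to compound 3 (0.43 log units; beyond the scatter), a modest step that concerns the side chain alone.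

Compound 4 `O=C(/C=C/OC1=CC=C1)Nc1nc2ccc([N+](=O)[O-])cc2s1` differs from compound 2 in that (nitro in place of chloro on an aromatic carbon). Among the compounds with values here, this change sits on the fused ring, where all three measured compounds are the same, so no measured step speaks to it directly; the step from compound 2 to compound 3 lies elsewhere in the molecule. Within the data shown here, with no comparable pair to lean on, the expectation in this assay is for a step within the scatter, a 1.1-fold lower number from compound 2 to compound 4 (0.04 log units; within the scatter), held with low confidence and a wide range. Compound 4 is accordingly estimated at 500 umol/kg in this assay, with a range from 200 umol/kg to 1300 umol/kg.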

Compound 4, dose for half-maximal effect: 597 umol/kg
Compound 4: the middle estimate sits 1.2-fold (0.08 log units) below what was measured; the range from low to high includes it.
By their numbers in this assay, from the lowest: compound 1; then compound 3; then compounds 2 and 4 (each within the scatter of the next).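

Nitro in place of chloro on this aromatic carbon gives, in this assay, a 1.1-fold higher number from compound 2 to compound 4 (0.04 log units; within the scatter), so the two groups cannot be told apart here, although nitro brings three heavy atoms and two hydrogen-bond acceptors where chloro has one heavy atom and no acceptors. Going by these compounds alone, all the earlier compounds carried chloro on the fused ring and their one readable step concerned the side chain alone, so this pair is the first direct reading at this position, and it shows that this exchange leaves the number within the scatter, at least with the side chain shared by compound 2 and compound 4. Nothing available accounts for why the two groups read alike.

From the compounds shown here alone, whether an amine or a carboxylic acid on this aromatic carbon would read the same remains open, since both groups compared here have no hydrogen-bond donors and no net charge. Going by these compounds, it is also open whether nitro in place of chloro would give an equally small step with the side chains of compound 1 and compound 3.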